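A few compounds are considered here, and "the series" means these few. Any claim that something is new, unique, unknown or untested is made for them only; others in the source may bear on it.

In a functional assay on MDA-MB-231 cells (Homo sapiens) for cytotoxicity, read by MTT assay, with a stated time of 48 h (on this read-out lower numbers stand for stronger inhibition and higher numbers for weaker inhibition), compound 1 `CC(C)c1cccc(OC(=O)c2cn(-c3ccccc3)nc2-c2cccnc2)c1` returns only a limit, > 100000 nM. Compound 2 `Cc1ccc(C(C)C)c(OC(=O)c2cn(-c3ccccc3)nc2-c2cccnc2)c1` likewise returns only a limit in this assay, namely > 100000 nM. The step that the two limits leave unreadable from compound 1 to compound 2 therefore cannot be read. For the measured compounds named here, compound 2 thus stands at the same place as the one other value shown, at the limit of > 100000 nM in this assay, at which 2 of the 2 values shown sit, and no number places it anywhere within the measured range. Compound 3 `Cc1ccc(C(C)C)c(OC(=O)c2cn(-c3ccccc3)nc2-c2ccncc2)c1` keeps every atom of compound 2 and differs only in pyridin-4-yl in place of pyridin-3-yl on an aromatic carbon. No measured step touches this change, and the single step shown is itself unreadable, so nothing in the data points to a direction. The expectation for compound 3 is accordingly that it again lies at the limit, with an estimated value of 150000 nM spanning 30000 nM to 600000 nM. The expected step that the limit leaves unreadable from compound 2 to compound 3 is therefore put at none beyond the scatter.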

Compound 3, half-maximal inhibitory concentration: > 100000 nM
Compound 3: no number, only a limit; the forecaster's own chance of this, stated with the estimate: 80%; the middle value lies beyond the limit too.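

In this assay compound 3 returns only a limit, > 100000 nM, and compound 2 also returned only a limit, so the step between compound 2 and compound 3 cannot be read. The compounds shown leave open whether pyridin-4-yl and pyridin-3-yl differ at all in this read-out.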